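From 2-fluorophenoxy to 3-fluorophenoxy

This account rests on a few compounds, and the source may have more. Where it says the series, first, only, none or still open, it means among the compounds named here.

Measured in a functional assay on Jurkat cells (Homo sapiens) (a lower number here means a stronger inhibitor, a higher number a weaker inhibitor), so far:
Compound 1 `CC(C)[C@H](NC(=O)COc1cccc2ccccc12)C(=O)N[C@@H](CC(=O)O)C(=O)COC(=O)c1c(Cl)cccc1Cl` gives 10600 nM
Compound 2 `CC(C)[C@H](NC(=O)COc1cccc2ccccc12)C(=O)N[C@@H](CC(=O)O)C(=O)COc1ccccc1C(F)(F)F` gives > 100000 nM (a limit)
Compound 3 `CC(C)[C@H](NC(=O)COc1cccc2ccccc12)C(=O)N[C@@H](CC(=O)O)C(=O)COc1ccccc1F` gives > 100000 nM (a limit)

Compound 3 gives no number, only a limit (the limit of > 100000 nM in this assay, at which 2 of the 3 values shown sit). In compound 4 `CC(C)[C@H](NC(=O)COc1cccc2ccccc12)C(=O)N[C@@H](CC(=O)O)C(=O)COc1cccc(F)c1` 3-fluorophenyl stands in place of 2-fluorophenyl on an oxygen on a saturated carbon (3-fluorophenyl in place of 2-fluorophenyl on an oxygen on a saturated carbon). Among the measured compounds shown here, two steps bear on this change. They are an at least 9.4-fold higher number from compound 1 to compound 2 (0.97 log units; beyond the scatter) and an at least 9.4-fold higher number from compound 1 to compound 3 (0.97 log units; beyond the scatter) and both lie beyond the scatter and end at a limit. For the measured compounds named here, the step that the two limits leave unreadable from compound 2 to compound 3 cannot be read, and no measured step moves the fluoro group. No step beyond the scatter is therefore expected, and the estimated step is a number no higher from compound 3 to compound 4 (the limit leaves the size open) with a limit as the likely report. In this assay the expected value for compound 4 is 100000 nM with a range from 30000 nM to 300000 nM as estimated here.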

Compound 4, half-maximal inhibitory concentration: > 100000 nM
Compound 4 was reported as a limit; the forecaster's own chance of this, stated with the estimate: 75%; the middle value sits exactly at the limit.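

In this assay compound 4 gives > 100000 nM, which is a limit, so 3-fluorophenyl on this oxygen yields no number, just as 2-fluorophenyl did. Set against (2,6-dichlorophenyl)carbonyl, the 3-fluorophenyl group gives an at least 9.4-fold higher number from compound 1 to compound 4 (0.97 log units; beyond the scatter), while the steps among compound 2, compound 3 and compound 4 cannot be read. Thus all three phenyl groups on this oxygen end at the same limit: the limit of > 100000 nM in this assay, at which 3 of the 4 values shown sit.

On these data alone, how far these compounds lie beyond that limit stays open. So does whether an amine or a carboxylic acid in place of the fluoro group would give a measurable value.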